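Swapping the Chain-End Amine in Compound 2

The source may report more compounds than this note shows. Statements on the series, on what has been measured and on what is new or still open speak of the compounds shown alone.

Compound 2 `COc1ccc(-c2ccnc(C(=O)Nc3ccc(Oc4ccnc5cc(OCCCN6CCN(C)CC6)c(OC)cc45)c(F)c3)c2)cc1` was tested in a functional assay on NCI-H460 cells (Homo sapiens) for cytotoxicity, read by MTT assay, with a stated time of 72 h (a higher number here means a weaker inhibitor, a lower number a stronger inhibitor), and gave 370 nM. Going by the values given here, of the two measured compounds it has the higher number: compound 1 `COc1cc2c(Oc3ccc(NC(=O)c4cc(-c5ccc(C(F)(F)F)cc5)ccn4)cc3F)ccnc2cc1OCCCN1CCN(C)CC1` gave 160 nM, and the single recorded step, a 2.3-fold higher number from compound 1 to compound 2 (0.36 log units; beyond the scatter), separates them. Compound 3 `COc1ccc(-c2ccnc(C(=O)Nc3ccc(Oc4ccnc5cc(OCCCN6CCCC6)c(OC)cc45)c(F)c3)c2)cc1` differs from compound 2 in one place: pyrrolidin-1-yl in place of 4-methylpiperazin-1-yl on a saturated chain carbon, three bonds along the chain from an oxygen on an aromatic ring. Among the compounds with values here, no measured step touches this part of the molecule. Within the data shown here, the only step available, from compound 1 to compound 2, concerns a group on an aromatic ring elsewhere in the structure and therefore gives no direct guide to what the chain-end amine contributes. With nothing to set a direction, the expected step in this assay is none beyond the scatter. Compound 3 is therefore estimated at 370 nM, with a range from 150 nM to 900 nM, which means an expected step of no change at the digits printed from compound 2 to compound 3 (within the scatter).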

Compound 3, half-maximal inhibitory concentration: 200 nM
Compound 3: middle estimate off by 1.9-fold (0.27 log units), on the high side, within the range that was stated.
By their numbers in this assay, from the lowest: compounds 1, 3 and 2 (each within the scatter of the next, the first and the last beyond it).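

The end of the 3-(4-methylpiperazin-1-yl)propyl chain accepts pyrrolidin-1-yl with no shift that can be told from scatter in this assay: the step is a 1.9-fold lower number from compound 2 to compound 3 (0.27 log units; within the scatter). A five-membered ring with 1 hetero atom therefore serves here as well as a six-membered ring with 2 hetero atoms, so, for this pair, the methyl-bearing second ring nitrogen of 4-methylpiperazin-1-yl is not needed to keep the number in this range. Nothing available explains this outcome or links it to any property of either group.

On these data alone, whether other chain-end amines, such as morpholin-4-yl, piperidin-1-yl or an open-chain dimethylamino group, would also sit within the scatter remains open. Also open, as far as these compounds go, are a shorter chain carrying the same amine, as in 2-(pyrrolidin-1-yl)ethyl, and whether the same exchange gives a similar step with trifluoromethyl in place of methoxy.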